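Moving Two Fluorines on the Phenoxy Ring

A few compounds are considered here, and "the series" means these few. Any claim that something is new, unique, unknown or untested is made for them only; others in the source may bear on it.

Compounds measured in a functional assay on Jurkat cells (Homo sapiens); on this read-out lower numbers stand for stronger inhibition and higher numbers for weaker inhibition:
- Compound 1 `CC(C)[C@H](NC(=O)COc1cccc2ccccc12)C(=O)N[C@@H](CC(=O)O)C(=O)COc1ccc(C(N)=O)cc1`: > 100000 nM (a limit)
- Compound 2 `CC(C)[C@H](NC(=O)COc1cccc2ccccc12)C(=O)N[C@@H](CC(=O)O)C(=O)COc1ccccc1[N+](=O)[O-]`: > 100000 nM (a limit)
- Compound 3 `CC(C)[C@H](NC(=O)COc1cccc2ccccc12)C(=O)N[C@@H](CC(=O)O)C(=O)COc1ccc(F)cc1F`: 33200 nM

Going by the values given here, compound 3 holds the only true number in this small set, since the values of compound 1 and compound 2 are limits of the assay. The next candidate is compound 4 `CC(C)[C@H](NC(=O)COc1cccc2ccccc12)C(=O)N[C@@H](CC(=O)O)C(=O)COc1cc(F)cc(F)c1`, which has not yet been measured in this assay. The change is 3,5-difluorophenyl in place of 2,4-difluorophenyl on an oxygen on a saturated carbon, with 3,5-difluorophenyl in place of 2,4-difluorophenyl on an oxygen on a saturated carbon.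

Among the compounds with values here, two measured steps bear on it: an at least 3.0-fold lower number from compound 1 to compound 3 (0.47 log units; beyond the scatter) and an at least 3.0-fold lower number from compound 2 to compound 3 (0.47 log units; beyond the scatter). Both lie beyond the scatter, but each is only a bound, and each exchanges a different group for 2,4-difluorophenyl. Neither shows what happens when the two fluorines move, so they give no reason to expect a large shift in either direction. They do show how close the ceiling is: the limit of > 100000 nM in this assay, at which 2 of the 3 values shown sit.

The expected change is therefore small, and the step expected is a 1.2-fold higher number from compound 3 to compound 4 (0.08 log units; within the scatter), which would not stand beyond the scatter. For compound 4 the estimated value is 40000 nM, with an expected range from 15000 nM to 100000 nM.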

Compound 4, half-maximal inhibitory concentration: > 100000 nM
Compound 4: only a limit was reported; the forecaster's own chance of this, stated with the estimate: 20%; middle value at least 2.5-fold (0.39 log units) from the limit.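

In this assay, putting 3,5-difluorophenyl in place of 2,4-difluorophenyl on an oxygen on a saturated carbon gives an at least 3.0-fold higher number from compound 3 to compound 4 (0.47 log units; beyond the scatter). The earlier steps shown here each exchanged one group for a different kind of group, whereas here the atoms stay the same and only the way they are joined differs, so this position responds to where the two fluorines sit and not only to which atoms are present. The steps joining compound 4 to compound 1 or compound 2 cannot be read, and the step from compound 3 gives a bound rather than a size, leaving compound 3 as the only compound in the set with a true number: the limit of > 100000 nM in this assay, at which 3 of the 4 values shown sit.

The compounds shown do not tell which of the two fluorines in compound 3 counts for more, since neither a phenyl ring with a single fluorine nor an unsubstituted phenyl is among them. Going by these compounds, compound 3 gives 33200 nM, and whether a chlorophenyl or a methoxyphenyl at this place would give a clearly lower number also stays open.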